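The source may hold more compounds than are shown below. What is called first, only, known or untested is meant among the compounds shown, and "the series" means these compounds.

Measured so far in a functional assay on HeLa cells (Homo sapiens) for antiproliferative activity, read by MTT assay, with a stated time of 72 h; a lower number here means a stronger inhibitor, a higher number a weaker inhibitor:
compound 1 `COc1ccc(N2C(=O)COc3ccc(-c4cnc(OC)c(NS(=O)(=O)c5ccc(F)cc5)c4)cc32)cc1`: 1220 nM
compound 2 `O=C1COc2ccc(-c3cccc(NS(=O)(=O)c4ccc(F)cc4)c3)cc2N1c1ccc(F)cc1`: a limit of the assay, > 40000 nM

Compound 2 sits at the limit of this assay and carries no number (the limit of > 40000 nM in this assay, at which 1 of the 2 values shown sits). Compound 1 gives 1220 nM in this assay. Within the data shown here, compound 1 differs from compound 2 in more than one place, so the two values give no single step, only the contrast between a measured number and a limit.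

Compound 3 `COc1cccc(N2C(=O)COc3ccc(-c4cccc(NS(=O)(=O)c5ccc(F)cc5)c4)cc32)c1` is compound 2 changed in one place: 3-methoxyphenyl in place of 4-fluorophenyl on an amide-type nitrogen in a ring. The change brings in the 3-methoxyphenyl group on the amide-type nitrogen in the ring. Among the measured compounds shown here, no measured pair isolates this change. Compound 1 also carries a methoxyphenyl group on that nitrogen and gives 1220 nM, but its other differences keep this from being a clean comparison. A modest gain is expected, an at least 2.6-fold lower number from compound 2 to compound 3 (0.42 log units; beyond the scatter). Compound 3 is estimated at 15000 nM, in the range 3000 nM to 60000 nM.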

Compound 3, half-maximal inhibitory concentration: > 40000 nM
Compound 3: a limit, no number; the forecaster's own chance of this, stated with the estimate: 40%; middle value at least 2.6-fold (0.42 log units) away from the limit.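

No step can be read from compound 2 to compound 3 in this assay, since each compound gives only a limit: the limit of > 40000 nM in this assay, at which 2 of the 3 values shown sit.

The compounds shown leave open whether 3-methoxyphenyl in place of 4-fluorophenyl on the amide-type nitrogen in the ring changes activity at all on a core that gives a measurable number, such as that of compound 1.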